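Trifluoromethoxy in Place of Fluoro on the Phenoxy Ring

The source may report more compounds than this note shows. Statements on the series, on what has been measured and on what is new or still open speak of the compounds shown alone.

Of the compounds shown here, three sharing one core have been measured in an assay on HEK293 cells for agonist activity at prostaglandin E2 receptor EP2 subtype (Homo sapiens), read by a beta-galactosidase reporter and beta-arrestin recruitment, with a stated time of 90 min; a lower number here means that less compound is needed, a higher number that more compound is needed for the effect. Compound 1 `O=C(O)c1csc([C@H]2CC[C@@H]3[C@@H](COc4ccccc4F)[C@H](O)C[C@@H]3O2)n1` carries a 2-fluorophenyl on an oxygen on a saturated carbon; in this assay compound 1 gives > 10000 nM, which is a limit of the assay and not a number. Compound 2 `O=C(O)c1csc([C@H]2CC[C@@H]3[C@@H](COc4cccc(F)c4)[C@H](O)C[C@@H]3O2)n1` carries a 3-fluorophenyl at the same oxygen; in this assay compound 2 gives > 10000 nM, again a limit. Compound 3 `O=C(O)c1csc([C@H]2CC[C@@H]3[C@@H](COc4ccc(F)cc4)[C@H](O)C[C@@H]3O2)n1` carries a 4-fluorophenyl; in this assay compound 3 gives > 10000 nM, also a limit. Because (the limit of > 10000 nM in this assay, at which 3 of the 3 values shown sit), the steps a step that the two limits leave unreadable from compound 1 to compound 2, a step that the two limits leave unreadable from compound 1 to compound 3 and a step that the two limits leave unreadable from compound 2 to compound 3 cannot be read. Compound 2 thus stands at the limit, as do the other two values.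

Compound 4 `O=C(O)c1csc([C@H]2CC[C@@H]3[C@@H](COc4cccc(OC(F)(F)F)c4)[C@H](O)C[C@@H]3O2)n1` differs from compound 2 by trifluoromethoxy in place of fluoro on an aromatic carbon. Among the measured compounds shown here, no measured step bears on this change: every step between the measured compounds is unreadable, so no direction and no size can be drawn from them. The step that the limit leaves unreadable from compound 2 to compound 4 is therefore expected to be at most the scatter, with a strong chance that the assay again reports only a limit. Compound 4 is expected at about 15000 nM, within a range from 3000 nM to 60000 nM.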

Compound 4, half-maximal effective concentration: 69 nM
Estimate against measurement, compound 4: 220-fold (2.34 log units) above; measured number outside the range, below it.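

In this assay, trifluoromethoxy in place of fluoro on this aromatic carbon gives an at least 140-fold lower number from compound 2 to compound 4 (2.16 log units; beyond the scatter), which shows that a change at this place, meta to a large group, can bring the shared core into the readable range of the assay. Compound 2 gives > 10000 nM, which is a limit of the assay and not a number, so the step has a lower bound but no known full size. The three compounds carrying a fluorophenyl could not show this sensitivity, and the steps among them cannot be read: the limit of > 10000 nM in this assay, at which 3 of the 4 values shown sit.

The compounds shown leave open which part of the trifluoromethoxy group matters, as a methoxy or a trifluoromethyl on the same aromatic carbon would be needed to separate the oxygen from the fluorines. They also leave open whether trifluoromethoxy gives a readable number on the other carbons of the ring, and whether a chloro or a longer chain such as ethoxy at this place would do the same.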